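This account rests on a few compounds, and the source may have more. Where it says the series, first, only, none or still open, it means among the compounds named here.

Working notes on the series, read in a toxicity assay on MT2 cells (Homo sapiens) for cytotoxicity; a lower number here means that less compound is tolerated, a higher number that more compound is tolerated. Compound 1 `Cc1nc(C)c([C@H](OC(C)(C)C)C(=O)O)c(N2CCC(C)(C)CC2)c1-c1ccc2c(c1)CCN(Cc1cccc(F)c1C)C2` gives only a limit, >= 24000 nM. Compound 2 `Cc1nc(C)c([C@H](OC(C)(C)C)C(=O)O)c(N2CCC(C)(C)CC2)c1-c1ccc2c(c1)CCN(Cc1ccc(F)cc1F)C2` also gives only a limit, >= 24000 nM. Compound 2 therefore has no numerical position in the series, and the evidence so far is the limit of >= 24000 nM in this assay, at which 2 of the 2 values shown sit.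

The next structure is compound 3 `Cc1nc(C)c([C@H](OC(C)(C)C)C(=O)O)c(N2CCC(C)(C)CC2)c1-c1ccc2c(c1)CCN(c1nccc(-c3cnccn3)n1)C2`, and the change is a group of 12 heavy atoms (8 carbon, 4 nitrogen; 2 six-membered aromatic rings with 2 hetero atoms each) in place of a group of 9 heavy atoms (7 carbon, 2 fluorine; one six-membered aromatic ring of carbon only), on an amine nitrogen in a ring. Neither group carries a net charge.

Going by the values given here, one measured step bears on this change, since it also alters the group on the same amine nitrogen in a ring. That step is a step that the two limits leave unreadable from compound 1 to compound 2, so it gives no size to carry over. Its replacement also stays a benzyl-type group with a single six-membered aromatic ring of carbon only, whereas the entering group has 2 six-membered aromatic rings with 2 hetero atoms each. No direction can be drawn from the data, so no shift beyond the scatter is expected, and another limit is the most likely report. The expected step is a number no higher from compound 2 to compound 3 (the limit leaves the size open). For compound 3 the estimate is 24000 nM, with an expected range from 10000 nM to 50000 nM.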

Compound 3, half-maximal cytotoxic concentration: >= 17000 nM
Compound 3: only a limit was reported (the forecaster's own chance of this, stated with the estimate: 65%); the middle value does not contradict the limit.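

In this assay compound 3 gives >= 17000 nM, which is a limit and not a number. Going by these compounds alone, compound 1 and compound 2 are also limits, so no step among compound 1, compound 2 and compound 3 can be read. The compounds shown leave open whether changing the group on the amine nitrogen in a ring shifts tolerance at all.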